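Taking One Chloro Group Off Compound 1

A few compounds are considered here, and "the series" means these few. Any claim that something is new, unique, unknown or untested is made for them only; others in the source may bear on it.

Of the compounds shown here, two have been measured so far. In a functional assay (a lower number here means a stronger inhibitor, a higher number a weaker inhibitor), compound 1 (`O=C(O)C1CS[C@@H](c2cccc(Cl)c2Cl)N1`) gives 930 nM, and compound 2 (`O=C(O)C1CS[C@@H](c2cccc(F)c2F)N1`) gives 830 nM. These two numbers lie within the usual scatter of repeated measurements, so they cannot be ranked, and compound 1 stands level with compound 2.

For the measured compounds named here, the next compound to be tested is compound 3 (`O=C(O)C1CS[C@@H](c2cccc(Cl)c2)N1`), which has no measurement yet. Its structure differs from that of compound 1 in one place: hydrogen in place of chloro on an aromatic carbon. In words, hydrogen takes the place of chloro on an aromatic carbon, ortho to a chloro group, and that remaining chloro group stays.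

Going by the values given here, no pair of measured compounds shows this change on its own, so any forecast is loose. A modest loss of strength in this assay, seen as a higher number, seems more likely than a gain. The estimated change is a 1.6-fold higher number from compound 1 to compound 3 (0.21 log units; within the scatter), which is a small step. For compound 3, the expected value is 1500 nM, with an estimated range from 450 nM to 5000 nM.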

Compound 3, half-maximal inhibitory concentration: 1520 nM
Compound 3: middle estimate off by 1.0-fold (0.01 log units), on the low side; low and high end bracket the measured number.
By their numbers in this assay, from the lowest: compounds 2, 1 and 3 (each within the scatter of the next).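

In this assay, for the compounds shown here, hydrogen in place of chloro on an aromatic carbon, ortho to a chloro group, gives a 1.6-fold higher number from compound 1 to compound 3 (0.21 log units; within the scatter) and is the first single change here that can be read on its own. The step lies within the scatter, so compound 1 and compound 3 stand level, and at this position the chloro group of compound 1 can give way to hydrogen with no change that this assay can distinguish: compound 3 reads 1520 nM and cannot be ranked against compound 1. Nothing measured here offers a reason for this result.

The compounds shown leave open what a different group at this position would do, such as a methoxy group or an amine, as the only single change read there so far is from chloro to hydrogen. Also open is what the remaining chloro group contributes, as no step shown here alters that group on its own.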